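Swapping a Furan for a Nitrile on the Shared Core

This account rests on a few compounds, and the source may have more. Where it says the series, first, only, none or still open, it means among the compounds named here.

Compound 1 `C=Cc1ccc(-c2cc(C)c3ncc(CSCCc4ccccc4)n3c2)cc1` — 20 ug/mL
Compound 2 `Cc1cc(-c2ccoc2)cn2c(CSCCc3ccccc3)cnc12` — > 4 ug/mL

In an ADME assay on HEL cells (Homo sapiens) for cytotoxicity, with a stated time of 3 days (a higher number here means that more compound is tolerated, a lower number that less compound is tolerated), compound 1 gives 20 ug/mL. For compound 2 the result in this assay is only a limit, > 4 ug/mL, not a number; this is the limit of > 4 ug/mL in this assay, at which 1 of the 2 values shown sits. Because of that limit, the step that the limit leaves unreadable from compound 1 to compound 2 cannot be read. Compound 3 `Cc1cc(C#N)cn2c(CSCCc3ccccc3)cnc12` differs from compound 2 by cyano in place of furan-3-yl on an aromatic carbon. Within the data shown here, no measured step in this assay can be read for this change, so nothing foreseeable beyond the scatter is expected in either direction. Compound 3 is therefore estimated at 20 ug/mL, within 4 ug/mL to 100 ug/mL, which is an expected step that the limit leaves unreadable from compound 2 to compound 3.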

Compound 3, minimum cytotoxic concentration: 20 ug/mL
Estimate against measurement, compound 3: no gap at the digits printed; the range from low to high includes it.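

In this assay, cyano in place of 4-vinylphenyl on this aromatic carbon gives no change at the digits printed from compound 1 to compound 3 (within the scatter). This position therefore carries either a cyano group with no ring or a 4-vinylphenyl group with no readable difference between these two compounds. Compound 2 has only a limit, so its steps to compound 1 and compound 3 cannot be read, and furan-3-yl cannot be ranked against either group: the limit of > 4 ug/mL in this assay, at which 1 of the 3 values shown sits.

Still open, as far as these compounds go, is how an amine or a carboxylic acid on this same carbon would behave in this assay.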